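Acid-ring halogen swap on the cyclopentylmethyl ketone series

A few compounds are considered here, and "the series" means these few. Any claim that something is new, unique, unknown or untested is made for them only; others in the source may bear on it.

Working notes on a short set of phenolic ketones bearing a four-carbon chain to a benzoic acid. Compound 1 `Cc1c(OCCCCOc2ccc(C(=O)O)c(Cl)c2)ccc(C(=O)CC(C)C)c1O` in an assay on HEK293 cells for positive allosteric modulation of metabotropic glutamate receptor 3 (Rattus norvegicus), read by thallium flux, with a stated time of 2.5 min (on this read-out lower numbers stand for an effect already at smaller amounts and higher numbers for an effect only at larger amounts of compound), gives 2050 nM. Compound 2 `Cc1c(OCCCCOCOc2ccc(C(=O)O)cc2)ccc(C(=O)CC2CCCC2)c1O` in this assay gives 1910 nM. Compound 3 `Cc1c(OCCCCOc2ccc(C(=O)O)cc2F)ccc(C(=O)CC2CCCC2)c1O` in this assay reaches only the limit > 10000 nM, so no number is known for it; it sits at the limit of > 10000 nM in this assay, at which 1 of the 3 values shown sits. For the measured compounds named here, the one measured step, an at least 5.2-fold higher number from compound 2 to compound 3 (0.71 log units; beyond the scatter), therefore has only a lower bound.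

Compound 4 `Cc1c(OCCCCOc2ccc(C(=O)O)c(Cl)c2)ccc(C(=O)CC2CCCC2)c1O` is not yet measured. The change from compound 3 is 4-carboxy-3-chlorophenyl in place of 4-carboxy-2-fluorophenyl on an oxygen on a saturated carbon. Going by the values given here, no measured step carries this exact change; the closest comparison is compound 1, which carries the same 4-carboxy-3-chlorophenyl on the same chain with a different ketone side chain and gives 2050 nM, while compound 2 with the cyclopentylmethyl ketone gives 1910 nM. Both of these sit near the same value, so compound 4 is expected to return from the limit to the range of compound 1 and compound 2. Compound 4 is expected to give 2500 nM, within 800 nM to 8000 nM. The expected step is an at least 4.0-fold lower number from compound 3 to compound 4 (0.60 log units; beyond the scatter), though its size rests on a limit.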

Compound 4, half-maximal effective concentration: 2250 nM
Compound 4: middle estimate off by 1.1-fold (0.05 log units), on the high side; low and high end bracket the measured number.
By their numbers in this assay, from the lowest: compounds 2, 1 and 4 (each within the scatter of the next). At a limit, above all of these: compound 3.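

Putting 4-carboxy-3-chlorophenyl in place of 4-carboxy-2-fluorophenyl, with the rest of the molecule unchanged, gives in this assay an at least 4.4-fold lower number from compound 3 to compound 4 (0.64 log units; beyond the scatter), so a measurable number is regained with the cyclopentyl ketone. Compound 3 remains a limit and not a number: the limit of > 10000 nM in this assay, at which 1 of the 4 values shown sits. Cyclopentyl in place of isopropyl on a saturated chain carbon bound to a carbonyl carbon gives a 1.1-fold higher number from compound 1 to compound 4 (0.04 log units; within the scatter), and 4-carboxy-3-chlorophenyl in place of (4-carboxyphenoxy)methyl gives a 1.2-fold higher number from compound 2 to compound 4 (0.07 log units; within the scatter), so among the compounds shown only compound 3, with its 4-carboxy-2-fluorophenyl, stands apart.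

The halogen and its numbered place differ together between compound 3 and compound 4, so the two remain unseparated; 4-carboxy-3-fluorophenyl and 4-carboxy-2-chlorophenyl would separate them. Also open, going by these compounds, is how a tetrazole in place of the carboxylic acid would read.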